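This account rests on a few compounds, and the source may have more. Where it says the series, first, only, none or still open, it means among the compounds named here.

Measured in a functional assay on MDA-MB-231 cells (Homo sapiens) for antiproliferative activity, read by sulforhodamine B assay, with a stated time of 48 h; a higher number here means a weaker inhibitor of growth, a lower number a stronger inhibitor of growth:
- compound 1 `CCCCCc1ccc(-c2cn(CCCN3C(=O)COc4ccccc43)nn2)cc1`: 5000 nM
- compound 2 `COc1ccc2cc(-c3cn(CCCN4C(=O)COc5ccccc54)nn3)ccc2c1`: 5000 nM
- compound 3 `COc1ccc(-c2cn(CCCN3C(=O)COc4ccccc43)nn2)cc1`: 41500 nM

Compound 3 has the highest number of the three, and compound 1 and compound 2 both show lower values. The next change leads to compound 4 `O=C1COc2ccccc2N1CCCn1cc(-c2cccnc2)nn1`, with pyridin-3-yl in place of 4-methoxyphenyl on an aromatic carbon of the five-membered aromatic ring with 3 nitrogen: pyridin-3-yl in place of 4-methoxyphenyl on an aromatic carbon.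

Within the data shown here, only one measured step bears on this, and only indirectly. Replacing pentyl with methoxy gave an 8.3-fold higher number from compound 1 to compound 3 (0.92 log units; beyond the scatter), a modest change beyond the scatter. Among the measured compounds shown here, no measured step replaces the six-membered aromatic ring itself, so direct precedent is lacking. In the three compounds, the larger groups at this end of the molecule go with the lower numbers, and pyridin-3-yl is smaller than 4-methoxyphenyl. A small rise in this assay is therefore expected, possibly none beyond the scatter. The estimated change is a 1.2-fold higher number from compound 3 to compound 4 (0.08 log units; within the scatter). For compound 4 the expected value is 50000 nM, with an estimated range of 18000 nM to 120000 nM.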

Compound 4, concentration for 50% growth inhibition: 3000 nM
Compound 4: the middle estimate sits 17-fold (1.22 log units) above what was measured; measured number outside the range, below it.
By their numbers in this assay, from the lowest: compounds 4, 1 and 2 (each within the scatter of the next); then compound 3.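

Replacing 4-methoxyphenyl with pyridin-3-yl gives a 14-fold lower number from compound 3 to compound 4 (1.14 log units; beyond the scatter) in this assay and shows that this aromatic carbon of the five-membered ring tolerates a large shift in the number when the attached six-membered aromatic ring is exchanged. Compound 4 carries the smaller group yet lies within the scatter of compound 1 and compound 2, so it goes against the link between larger groups and lower numbers seen in the first three compounds. No supporting data accompany these values to account for the step.

The single exchange changes both the ring nitrogen and the methoxy group, so the compounds shown cannot separate their contributions. Plain phenyl, pyridin-2-yl, pyridin-4-yl and an aminophenyl group at this position remain open.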